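From phenoxy to sulfanyl: compound 1 to compound 4

This account rests on a few compounds, and the source may have more. Where it says the series, first, only, none or still open, it means among the compounds named here.

Of the compounds shown here, three with a shared core have been measured in a functional assay on Hs-578T cells (Homo sapiens) for inhibition, read by sulforhodamine B assay, with a stated time of 48 h; on this read-out higher numbers stand for weaker inhibition of growth and lower numbers for stronger inhibition of growth. Compound 1 `Nc1cc(N)c2nc(-c3ccccc3)c(Oc3ccc(Cl)c(Cl)c3)nc2c1` gives 33900 nM in this assay. Compound 2 `Nc1cc(N)c2nc(-c3ccccc3)c(NCc3ccc(Cl)c(Cl)c3)nc2c1` gives 46800 nM in this assay, and compound 3 `COc1cc(CNc2nc3cc(N)cc(N)c3nc2-c2ccccc2)cc(OC)c1OC` gives 33100 nM. Among these three numbers compound 1 stands second highest; its nearest neighbour is compound 3, whose value lies within the scatter of it, and its furthest is compound 2, which also lies within the scatter, so no order among the three can be read from the data.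

Compound 4 `Nc1cc(N)c2nc(-c3ccccc3)c(Sc3ccc(Cl)c(Cl)c3)nc2c1` has not yet been measured. It differs from compound 1 in one place: (3,4-dichlorophenyl)sulfanyl in place of 3,4-dichlorophenoxy on an aromatic carbon. Among the compounds with values here, no two measured compounds differ from each other in a single place, so there is no measured step to lean on. The three existing values all sit within the scatter of one another even though the group attached to the core varies among them, which suggests that putting (3,4-dichlorophenyl)sulfanyl in place of 3,4-dichlorophenoxy is unlikely to move the number beyond the scatter. Compound 4 is therefore expected to give 32000 nM in this assay, with a range from 13000 nM to 80000 nM. The step of a 1.1-fold lower number from compound 1 to compound 4 (0.03 log units; within the scatter) is expected to stay within the scatter.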

Compound 4, concentration for total growth inhibition: < 100000 nM
Compound 4: a limit, no number; the forecaster's own chance of this, stated with the estimate: 10%; the middle value lies beyond the limit too.
By their numbers in this assay, from the lowest: compounds 3, 1 and 2 (each within the scatter of the next).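

In this assay compound 4 gives < 100000 nM as a limit of the assay and not as a number. Within the data shown here, no step from compound 1 to compound 4 can be read from it. The compounds shown leave open whether (3,4-dichlorophenyl)sulfanyl in place of 3,4-dichlorophenoxy on an aromatic carbon moves the number beyond the scatter.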